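Chain extension at the ring nitrogen methyl

The source may report more compounds than this note shows. Statements on the series, on what has been measured and on what is new or still open speak of the compounds shown alone.

For the measured compounds named here, compound 1 `Cn1c(Cc2nn(C)c(=O)c3ccccc23)nnc1SCC(=O)Nc1ccc(Cl)cc1Cl` is the only member with a numeric value: in an assay on NK92 cells for inhibition of interleukin-15 (Homo sapiens), read by AlphaScreen, with stated times of 30 min and 1 h (on this read-out higher numbers stand for weaker inhibition and lower numbers for stronger inhibition), compound 1 gives 4500 nM. Compound 2 `CCOC(CCn1c(Cc2nn(C)c(=O)c3ccccc23)nnc1SCC(=O)Nc1ccc(Cl)cc1Cl)OCC` reaches only a limit, giving > 30000 nM. Compound 3 `Cn1nc(Cc2nnc(SCC(=O)Nc3ccc(Cl)cc3Cl)n2CCC(=O)O)c2ccccc2c1=O` likewise stops at a limit, > 30000 nM. Two of the three values thus sit at the limit of > 30000 nM in this assay, at which 2 of the 3 values shown sit. Compound 4 `Cn1c(Cc2nn(CCC3OCCO3)c(=O)c3ccccc23)nnc1SCC(=O)Nc1ccc(Cl)cc1Cl` carries (1,3-dioxolan-2-yl)methyl in place of hydrogen on a saturated chain carbon bound to an aromatic nitrogen, a cyclic acetal where compound 2 has an open one. Going by the values given here, the measured steps that bear on it are an at least 6.6-fold higher number from compound 1 to compound 2 (0.82 log units; beyond the scatter) and an at least 6.6-fold higher number from compound 1 to compound 3 (0.82 log units; beyond the scatter), each a move from the one number into the limit. Given those two steps, for compound 4 a weakening step beyond the scatter, a 5.6-fold higher number from compound 1 to compound 4 (0.74 log units; beyond the scatter), is expected. For compound 4 the estimate is 25000 nM, range 6000 nM to 60000 nM, with a fair chance that only a limit is reported.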

Compound 4, half-maximal inhibitory concentration: 30000 nM
For compound 4 the middle estimate is 1.2-fold (0.08 log units) below the measured one; the range from low to high includes it.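

In this assay, a 6.7-fold higher number from compound 1 to compound 4 (0.82 log units; beyond the scatter) gives the first readable size for extending a methyl of compound 1, where the earlier extensions ended in a limit: the limit of > 30000 nM in this assay, at which 2 of the 4 values shown sit.

For the compounds shown here, the extension in compound 4 sits on the other aromatic nitrogen methyl, not the one changed in compounds 2 and 3, so weakening beyond the scatter now appears at both places.

Open, going by these compounds, is whether a plain propyl chain, or a chain ending in an amine or a carboxylic acid, on this nitrogen tracks with the (1,3-dioxolan-2-yl)methyl change.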